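Compound 4 and the ring substituent series

The source may report more compounds than this note shows. Statements on the series, on what has been measured and on what is new or still open speak of the compounds shown alone.

Of the compounds shown here, three sharing one core have been measured in an assay on CHO cells for binding affinity to metabotropic glutamate receptor 2 (Rattus norvegicus); on this read-out higher numbers stand for weaker inhibition and lower numbers for stronger inhibition. Compound 1 `N[C@]1(C(=O)O)[C@H]2[C@@H](C[C@H]1OCc1cccc(-c3ccccc3)c1)[C@]2(F)C(=O)O` gives 9.34 nM. Compound 2 `N[C@]1(C(=O)O)[C@H]2[C@@H](C[C@H]1OCc1cccc([N+](=O)[O-])c1)[C@]2(F)C(=O)O` gives 7.87 nM, and a 1.2-fold lower number from compound 1 to compound 2 (0.07 log units; within the scatter). Compound 3 `Nc1cccc(CO[C@@H]2C[C@@H]3[C@H]([C@]2(N)C(=O)O)[C@@]3(F)C(=O)O)c1` gives 15.4 nM; it stands next to the others, with a 1.6-fold higher number from compound 1 to compound 3 (0.22 log units; within the scatter) and a 2.0-fold higher number from compound 2 to compound 3 (0.29 log units; within the scatter), so all three sit within the scatter of one another.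

Compound 4 `N[C@]1(C(=O)O)[C@H]2[C@@H](C[C@H]1OCc1c(Cl)cccc1Cl)[C@]2(F)C(=O)O` carries 2,6-dichlorophenyl in place of 3-aminophenyl on a saturated chain carbon bound to an oxygen on a saturated carbon. Within the data shown here, no measured step exchanges one ring substituent pattern for a dichloro pattern, but the three changes that have been measured on that ring, from phenyl to nitro, from phenyl to amino and from nitro to amino, all stayed within the scatter. The expectation is therefore that compound 4 changes little from compound 3, the estimated step being a 1.3-fold lower number from compound 3 to compound 4 (0.11 log units; within the scatter). Compound 4 is estimated at 12 nM, with a range from 4 nM to 40 nM.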

Compound 4, inhibition constant: 4.3 nM
Compound 4: middle estimate off by 2.8-fold (0.45 log units), on the high side; the range from low to high includes it.
By their numbers in this assay, from the lowest: compounds 4, 2, 1 and 3 (each within the scatter of the next, the first and the last beyond it).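

In this assay putting 2,6-dichlorophenyl in place of 3-aminophenyl on a saturated chain carbon bound to an oxygen on a saturated carbon gives a 3.6-fold lower number from compound 3 to compound 4 (0.55 log units; beyond the scatter) and is the first step among these compounds to pass beyond the scatter, so the ring at this position can shift the number measurably. The shift has limits, since compound 4 remains within the scatter of compound 2, and the step separates compound 4 from compound 3 without setting it apart from every ring in the series. Nothing available here explains the step.

This one change removes the amino group, adds two chlorines and alters the substitution pattern, and the compounds shown cannot separate these parts. On these data alone, a ring with a single chlorine would help to separate them, while a methoxy group or a carboxylic acid on the ring remains open.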